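The compounds below may be only part of what the source reports. "The series", "measured", "known", "first", "only" and "open" are said of these compounds alone.

In a functional assay on HCC827 cells (Homo sapiens) for inhibition, read by MTT assay, with a stated time of 48 h, tested at 10 uM (on this read-out lower numbers stand for less inhibition and higher numbers for more inhibition at the one concentration tested (going by the name of the read-out)), three compounds have been measured so far:

compound 1, `COc1cc(NC(=O)Nc2cc(Nc3cc(F)ccc3OC)ncn2)cc(OC)c1`, gives 59%
compound 2, `COc1cc(Br)ccc1Nc1cc(NC(=O)Nc2c(Cl)cccc2Cl)ncn1`, gives 42.7%
compound 3, `COc1cc(NC(=O)Nc2cc(Nc3cc(I)ccc3OC)ncn2)cc(OC)c1`, gives 71%

Compound 3 stands highest of these three numbers. The nearest is compound 1, whose value lies below it by a number 12 percentage points higher from compound 1 to compound 3 (beyond the scatter), a difference beyond the scatter. Compound 2 lies furthest away, and the two values show it well below compound 3.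

The next compound, compound 4, is `COc1cc(NC(=O)Nc2cc(Nc3ccc(Br)cc3OC)ncn2)cc(OC)c1`. Relative to compound 3 it differs in one place: 4-bromo-2-methoxyphenyl in place of 5-iodo-2-methoxyphenyl on a nitrogen on an aromatic ring.

Among the measured compounds shown here, only one measured step bears on this change, the one from compound 1 to compound 3, in which the halogen on the same ring was exchanged and the number rose by a number 12 percentage points higher from compound 1 to compound 3 (beyond the scatter), a modest step. Here the halogen is exchanged again, and it also moves to a different named position on that ring, for which no measured step exists. For the measured compounds named here, the one step that exists suggests that halogen exchange on this ring shifts this assay only modestly, so for compound 4 a small move downward or none beyond the scatter is expected. Compound 4 is therefore expected to give 62%, within 45% to 78%. The expected step would be a number 9 percentage points lower from compound 3 to compound 4 (within the scatter).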

Compound 4, a percentage reported as inhibition, at one concentration (the size of the read-out at that concentration, not a potency): 57.7%
Compound 4: the middle estimate sits 4.3 percentage points above what was measured; the measured number falls inside the stated range.
By their numbers in this assay, from the lowest: compound 2; then compounds 4 and 1 (each within the scatter of the next); then compound 3.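

In this assay, the 4-bromo-2-methoxyphenyl group on this nitrogen cannot be told apart from the 5-fluoro-2-methoxyphenyl group (a number 1.3 percentage points lower from compound 1 to compound 4 (within the scatter)), whereas the 5-iodo-2-methoxyphenyl group stays clear of it (a number 13.3 percentage points lower from compound 3 to compound 4 (beyond the scatter)), so among these three groups only the one in compound 3 stands apart. Among the compounds shown here, with the 4-bromo-2-methoxyphenyl group held the same, the other end of the molecule also moves the number, as 3,5-dimethoxyphenyl in place of 2,6-dichlorophenyl on the amide-type nitrogen shows (a number 15 percentage points higher from compound 2 to compound 4 (beyond the scatter)), a place at which the earlier compounds offered no step. Nothing at hand accounts for either difference.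

The change from compound 3 to compound 4 alters both the halogen and its named position on the ring, and the compounds shown do not separate these two changes. They also leave open how an amine or a carboxylic acid in place of the halogen on this ring would read in this assay.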